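The source may hold more compounds than are shown below. What is called first, only, known or untested is meant among the compounds shown, and "the series" means these compounds.

Measured compounds:
- compound 1, `CCC(CC)n1c(-c2ccc(OCc3c(-c4c(Cl)cccc4Cl)noc3C(C)C)cc2)nc2ccc(C(=O)O)cc21`, in an assay on Huh-7 cells for agonist activity at Bile acid receptor (Homo sapiens), read by a luciferase reporter (on this read-out lower numbers stand for an effect already at smaller amounts and higher numbers for an effect only at larger amounts of compound), compound 1 gives 0.8 nM
- compound 2, `CC(C)c1onc(-c2c(Cl)cccc2Cl)c1COc1ccc(-c2nc3ccc(C(=O)O)cc3n2Cc2ccc(F)cc2)cc1`, in this assay compound 2 gives 3.31 nM

Compound 2 stands at the highest of the two numbers in this assay; its nearest neighbour is compound 1, and the step of a 4.1-fold higher number from compound 1 to compound 2 (0.62 log units; beyond the scatter) lies beyond the scatter. Compound 3, `CC(C)c1onc(-c2c(Cl)cccc2Cl)c1COc1ccc(-c2nc3ccc(C(=O)O)cc3n2CC(C)(C)C)cc1`, has not yet been measured in this assay. It differs from compound 2 by tert-butyl in place of 4-fluorophenyl on a saturated chain carbon bound to an aromatic nitrogen.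

Among the compounds with values here, the only measured step that bears on this change is a 4.1-fold higher number from compound 1 to compound 2 (0.62 log units; beyond the scatter), where a 4-fluorobenzyl group on the aromatic nitrogen took the place of a branched alkyl group and the number rose modestly. Compound 3 moves back from the 4-fluorobenzyl group to a branched alkyl group, neopentyl, which is not the same as the pentan-3-yl of compound 1, so the step need not simply reverse. Compound 3 is therefore expected to show a modestly lower number than compound 2, a 2.2-fold lower number from compound 2 to compound 3 (0.34 log units; beyond the scatter), lying between the values of compound 1 and compound 2. Compound 3 is estimated at 1.5 nM in this assay, with a range from 0.5 nM to 4.5 nM.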

Compound 3, half-maximal effective concentration: 13 nM
Estimate against measurement, compound 3: 8.7-fold (0.94 log units) below, outside the stated range (above it).
By their numbers in this assay, from the lowest: compound 1; then compound 2; then compound 3.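

Read in this assay, the new result shows that the step from a 4-fluorobenzyl group to a branched alkyl group on the aromatic nitrogen does not have one fixed direction: neopentyl in place of 4-fluorobenzyl gives a 3.9-fold higher number from compound 2 to compound 3 (0.59 log units; beyond the scatter), whereas compound 1, with its pentan-3-yl group, has the lowest number of the three. The two branched alkyl groups therefore do not behave alike at this position, and neopentyl in place of pentan-3-yl gives a 16-fold higher number from compound 1 to compound 3 (1.21 log units; beyond the scatter), a large step that places them at the two ends of the series, with compound 2 in the middle. The data at hand offer no explanation for this order.

With only pentan-3-yl, 4-fluorobenzyl and neopentyl on this nitrogen, the compounds shown leave open which feature of the group governs the number, whether the branching carbon's place in the chain, the size of the group or the presence of a ring. An unbranched n-pentyl chain, an isobutyl group or a cyclohexylmethyl group on the same nitrogen would help to separate these possibilities.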